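Benzylsulfanyl variation in the shared core, compound 3 to compound 4

A few compounds are considered here, and "the series" means these few. Any claim that something is new, unique, unknown or untested is made for them only; others in the source may bear on it.

Three members of the series with the same core carry different aryl groups on the saturated chain carbon bound to a sulfur. Compound 1 `Cc1cc(S(=O)(=O)/N=C(\N)n2nccc2-c2ccccc2)c(SCc2ccccc2Cl)cc1Cl` gives 18000 nM in a functional assay on HCT-116 cells (Homo sapiens) for cytotoxicity, read by MTT assay, with a stated time of 72 h; on this read-out lower numbers stand for stronger inhibition and higher numbers for weaker inhibition. Compound 2 `Cc1cccc(CSc2cc(Cl)c(C)cc2S(=O)(=O)/N=C(\N)n2nccc2-c2ccccc2)c1` gives 6500 nM, and compound 3 `Cc1cc(S(=O)(=O)/N=C(\N)n2nccc2-c2ccccc2)c(SCc2cccc(Cl)c2)cc1Cl` gives 7000 nM. The change a 2.8-fold lower number from compound 1 to compound 2 (0.44 log units; beyond the scatter) and the change a 2.6-fold lower number from compound 1 to compound 3 (0.41 log units; beyond the scatter) are both beyond the scatter, whereas a 1.1-fold higher number from compound 2 to compound 3 (0.03 log units; within the scatter) is within it. Compound 3 therefore stands second highest of the three numbers, indistinguishable from compound 2 and well separated from compound 1.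

Compound 4 `Cc1ccc(CSc2cc(Cl)c(C)cc2S(=O)(=O)/N=C(\N)n2nccc2-c2ccccc2)cc1` differs from compound 3 in one place: 4-methylphenyl in place of 3-chlorophenyl on a saturated chain carbon bound to a sulfur. The step that bears most directly on this is the chloro-to-methyl swap on an aromatic carbon, a 1.1-fold higher number from compound 2 to compound 3 (0.03 log units; within the scatter), which stayed within the scatter. Among the compounds with values here, no measured step tests a 4-substituted ring, so the shift of the substituent around the ring is untested. The expected step of a 1.1-fold higher number from compound 3 to compound 4 (0.03 log units; within the scatter) is accordingly small, with no direction beyond the scatter. Compound 4 is estimated at 7500 nM with a range of 3000 nM to 18000 nM.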

Compound 4, half-maximal inhibitory concentration: 14000 nM
The estimate for compound 4 lay 1.9-fold (0.27 log units) below the measured number, within the range that was stated.
By their numbers in this assay, from the lowest: compounds 2, 3, 4 and 1 (each within the scatter of the next, the first and the last beyond it).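

The first test of one substituent at two places on the ring is 4-methylphenyl in place of 3-methylphenyl, where a 2.2-fold higher number from compound 2 to compound 4 (0.33 log units; beyond the scatter) is a modest step, so the place of the methyl on the ring has a measurable but small bearing on the number. Within the data shown here, the 4-methylphenyl group does not separate from either chloro ring, since a 2.0-fold higher number from compound 3 to compound 4 (0.30 log units; within the scatter) and a 1.3-fold lower number from compound 1 to compound 4 (0.11 log units; within the scatter) both remain within the scatter, and the gap seen earlier between the two chlorophenyl groups has no clean counterpart here. Nothing measured here accounts for the methyl step.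

The compounds shown leave open whether a chloro group would respond to the same ring shift as the methyl does. They also leave open how a nitrile, an amine or a carboxylic acid on the aryl ring, or a longer chain between sulfur and ring, would read.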